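Urea-linked quinazolines: amine variation on the terminal phenyl

The source may report more compounds than this note shows. Statements on the series, on what has been measured and on what is new or still open speak of the compounds shown alone.

Measured so far:
compound 1 `CCN(CC)Cc1ccc(NC(=O)Nc2ccc3ncnc(Nc4cccc(C(F)(F)F)c4)c3c2)cc1` — 3980 nM
compound 2 `CCN(CC)c1ccc(NC(=O)Nc2ccc3ncnc(Nc4cccc(C(F)(F)F)c4)c3c2)cc1` — 6460 nM

Both compounds share the core of compound 1 and differ only at the terminal phenyl ring. In a functional assay on A-431 cells (Homo sapiens) for antiproliferative activity, read by MTT assay, with a stated time of 72 h (on this read-out higher numbers stand for weaker inhibition and lower numbers for stronger inhibition), compound 1 gives 3980 nM and compound 2 gives 6460 nM. Within the data shown here, the only step measured, a 1.6-fold higher number from compound 1 to compound 2 (0.21 log units; within the scatter), is within the scatter, so the two numbers cannot be ordered. Compound 2 carries the higher of the two numbers, but its nearest neighbour, compound 1, lies within the scatter of it.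

Compound 3 `CN1CCN(c2ccc(NC(=O)Nc3ccc4ncnc(Nc5cccc(C(F)(F)F)c5)c4c3)cc2)CC1` is not yet measured. It differs from compound 2 in one place: 4-methylpiperazin-1-yl in place of diethylamino on an aromatic carbon. Among the measured compounds shown here, no measured step involves a 4-methylpiperazin-1-yl group, so nothing bears directly on this change; the one step available, from compound 1 to compound 2, was within the scatter, which suggests this part of the molecule has tolerated change without a large shift in this assay. The expected step of a 1.3-fold lower number from compound 2 to compound 3 (0.11 log units; within the scatter) is therefore taken as none beyond the scatter, with a wide range to cover the lack of a direct precedent. Compound 3 is expected to give 5000 nM in this assay, between 1500 nM and 16000 nM.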

Compound 3, half-maximal inhibitory concentration: 2200 nM
Estimate against measurement, compound 3: 2.3-fold (0.36 log units) above; low and high end bracket the measured number.
By their numbers in this assay, from the lowest: compounds 3, 1 and 2 (each within the scatter of the next, the first and the last beyond it).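

In this assay this position gives its first step beyond the scatter, a 2.9-fold lower number from compound 2 to compound 3 (0.47 log units; beyond the scatter), so the group on this aromatic carbon is not fully interchangeable, although the step is modest and rests on a single pair of compounds. Among these compounds, the second step, a 1.8-fold lower number from compound 1 to compound 3 (0.26 log units; within the scatter), stays within the scatter, so compound 3 cannot be ordered against compound 1, and the only separation in this set is the one that compound 3 makes from compound 2. Nothing at hand accounts for the separation that follows from replacing diethylamino with 4-methylpiperazin-1-yl.

Still open, on these data alone, is whether that step follows the six-membered ring itself or its second nitrogen, and a piperidin-1-yl or morpholin-4-yl group on the same aromatic carbon would bear on that question. Also open, as far as these compounds go, is how a 4-methylpiperazin-1-yl group would read when attached through a methylene, as the diethylamino group is in compound 1, since that pairing would show whether the linker matters with this amine.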